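The source may report more compounds than this note shows. Statements on the series, on what has been measured and on what is new or still open speak of the compounds shown alone.

Compound 1 `O=C(Nc1ccc(F)cc1CN1C(=O)c2ccccc2C1=O)c1ccccn1`, compound 2 `O=C(Nc1ccc(Cl)cc1CN1C(=O)c2ccccc2C1=O)c1cccnc1` and compound 3 `O=C(Nc1ccc(Cl)cc1CN1C(=O)c2ccccc2C1=O)c1ccccc1` share one core and differ in the group on the carbonyl carbon and in the halogen. In an assay on CHO cells for positive allosteric modulation of metabotropic glutamate receptor 5 (Homo sapiens), read by FLIPR (on this read-out higher numbers stand for an effect only at larger amounts of compound and lower numbers for an effect already at smaller amounts), compound 1 gives 1500 nM. In this assay compound 2 gives 35000 nM. Compound 3 reaches only the limit of this assay, giving > 100000 nM, which is a limit and not a number (the limit of > 100000 nM in this assay, at which 1 of the 3 values shown sits). Within the data shown here, the step of an at least 2.8-fold higher number from compound 2 to compound 3 (0.45 log units; beyond the scatter) is the only measured step, and it moved compound 3 out of the measurable range. Compound 4 `O=C(Nc1ccc(Cl)cc1CN1C(=O)c2ccccc2C1=O)C1CCCCC1` differs from compound 3 by cyclohexyl in place of phenyl on a carbonyl carbon. Among the measured compounds shown here, no measured step shows this change; compound 3 is at the limit, so compound 4 is expected to stay near it, with a step that the limit leaves unreadable from compound 3 to compound 4. Compound 4 is estimated at 120000 nM, between 30000 nM and 400000 nM.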

Compound 4, half-maximal effective concentration: 1500 nM
Compound 4: the middle estimate sits 80-fold (1.90 log units) above what was measured; measured number outside the range, below it.
By their numbers in this assay, from the lowest: compounds 1 and 4 (each within the scatter of the next); then compound 2. At a limit, above all of these: compound 3.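

In this assay, the ring on the carbonyl carbon need not be aromatic: cyclohexyl brings an at least 66-fold lower number from compound 3 to compound 4 (1.82 log units; beyond the scatter), and a 23-fold lower number from compound 2 to compound 4 (1.37 log units; beyond the scatter). The earlier step from pyridin-3-yl to phenyl could suggest that a ring nitrogen was needed, yet cyclohexyl, with only carbon in its ring, gives the lowest number of these three compounds. The first of these steps is only a minimum, as compound 3 stands at a limit: the limit of > 100000 nM in this assay, at which 1 of the 4 values shown sits.

From the compounds shown here alone, whether a smaller ring such as cyclopentyl, a nitrogen-containing ring such as piperidinyl, or an open chain such as butyl would serve as well remains open. So does whether cyclohexyl behaves the same with fluorine in place of chlorine on the shared core.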